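Hydroxy on the side chain: estimate for compound 4

This account rests on a few compounds, and the source may have more. Where it says the series, first, only, none or still open, it means among the compounds named here.

Measured so far:
compound 1, `CCn1cnc2ncnc(N)c21`, > 30000 nM
compound 2, `Nc1ncnc2ncn(CCO)c12`, > 30000 nM
compound 3, `CC(O)Cn1c(Br)nc2c(N)ncnc21`, 640 nM

In a functional assay on CHO cells for antagonist activity at adenosine receptor A2b (Homo sapiens) (on this read-out lower numbers stand for stronger inhibition and higher numbers for weaker inhibition), compound 1 gives > 30000 nM, which is a limit of the assay and not a number. Compound 2 gives > 30000 nM, likewise a limit. For the measured compounds named here, compound 3 gives 640 nM, the only number among the three. The change from compound 1 to compound 2 is hydroxy in place of hydrogen on a saturated chain carbon, two bonds along the chain from an aromatic nitrogen; the step that the two limits leave unreadable from compound 1 to compound 2 stays unreadable because both ends sit at the limit of > 30000 nM in this assay, at which 2 of the 3 values shown sit. The difference between the core of compound 3 and the core of compound 1 is not broken down here.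

Compound 4, `Nc1ncnc2c1nc(Br)n2CC(O)CO`, differs from compound 3 by hydroxy in place of hydrogen on a saturated chain carbon, two bonds along the chain from an oxygen on a saturated carbon. This is the same kind of change as that from compound 1 to compound 2, but the place differs: two bonds along the chain from an oxygen on a saturated carbon, rather than two bonds along the chain from an aromatic nitrogen. The earlier step gives no size to lean on, so the expectation for compound 4 rests on the value of compound 3, 640 nM, with an estimated step of a 1.4-fold higher number from compound 3 to compound 4 (0.15 log units; within the scatter) near the usual scatter. Compound 4 is estimated at 900 nM, between 300 nM and 3000 nM.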

Compound 4, inhibition constant: 7100 nM
Beside the measured number, compound 4's estimate is 7.9-fold (0.90 log units) below it; measured number above the stated range.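

In this assay, the change from 2-hydroxypropyl to 2,3-dihydroxypropyl on the core of compound 3 gives an 11-fold higher number from compound 3 to compound 4 (1.05 log units; beyond the scatter), so on this core the added hydroxy goes with clearly weaker inhibition. On the core of compound 1, the step to compound 2 puts a hydroxy in place of hydrogen at a different place on the chain, and it cannot be read, as both ends are limits of the assay: the limit of > 30000 nM in this assay, at which 2 of the 4 values shown sit. One readable step therefore stands alone, and it does not show whether a change of this kind has a similar size, or even the same direction, on another core.

The compounds shown leave open whether the weaker inhibition is specific to the hydroxy or would also appear with an amine or a carboxylic acid at the same place on the chain. They also leave open how a longer chain carrying a hydroxy would read on the core of compound 3.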